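Repositioning the Nitro Group: Cytotoxicity Outlook for Compound 4

A few compounds are considered here, and "the series" means these few. Any claim that something is new, unique, unknown or untested is made for them only; others in the source may bear on it.

Measured compounds:
compound 1, `N#Cc1c(-c2ccc(O)cc2)c(C#N)c(=O)n(/N=C/c2cn(-c3ccccc3)nc2-c2ccccc2)c1N`, in this assay: > 200 ug/mL
compound 2, `COc1ccc(-c2c(C#N)c(N)n(/N=C/c3cn(-c4ccccc4)nc3-c3ccccc3)c(=O)c2C#N)cc1`, in this assay: > 200 ug/mL
compound 3, `N#Cc1c(-c2ccccc2[N+](=O)[O-])c(C#N)c(=O)n(/N=C/c2cn(-c3ccccc3)nc2-c2ccccc2)c1N`, in this assay: > 200 ug/mL

Of the compounds shown here, three sharing one core have been tested in an ADME assay on HeLa cells (Homo sapiens) for cytotoxicity, read by MTT assay; a lower number here means a stronger inhibitor, a higher number a weaker inhibitor. In this assay compound 1 gives > 200 ug/mL, which is a limit of the assay and not a number. Compound 2 likewise gives > 200 ug/mL, a limit. Compound 3 gives > 200 ug/mL, again a limit. Accordingly, the steps a step that the two limits leave unreadable from compound 1 to compound 2, a step that the two limits leave unreadable from compound 1 to compound 3 and a step that the two limits leave unreadable from compound 2 to compound 3 cannot be read in size or direction; all three values sit at the limit of > 200 ug/mL in this assay, at which 3 of the 3 values shown sit.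

Compound 4, `N#Cc1c(-c2ccc([N+](=O)[O-])cc2)c(C#N)c(=O)n(/N=C/c2cn(-c3ccccc3)nc2-c2ccccc2)c1N`, is not yet measured. It differs from compound 3 by 4-nitrophenyl in place of 2-nitrophenyl on an aromatic carbon. All measured steps on this core bear on this change only in the sense that none of them could be read, and none pushed a compound below the limit. Compound 4 is therefore expected to give 250 ug/mL, with a range from 150 ug/mL to 450 ug/mL, and most likely only another limit. The step this estimate implies, a step that the limit leaves unreadable from compound 3 to compound 4, is expected to be none beyond the scatter.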

Compound 4, half-maximal inhibitory concentration: > 200 ug/mL
Compound 4: a limit, no number (the forecaster's own chance of this, stated with the estimate: 85%); the middle value is on the limit's open side.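

In this assay compound 4 gives > 200 ug/mL, which is a limit and not a number, so its steps from compound 1, compound 2 and compound 3 cannot be read: the limit of > 200 ug/mL in this assay, at which 4 of the 4 values shown sit. The compounds shown leave open how these four rank against one another, and whether any change on the shared core would give a readable value.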